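Aryl swap on the ring nitrogen of the shared core

A few compounds are considered here, and "the series" means these few. Any claim that something is new, unique, unknown or untested is made for them only; others in the source may bear on it.

Compound 2 `COc1ccc(-n2c(=O)c(C(=O)Nc3ccc(Oc4ccnc5[nH]ccc45)cc3)cc3cccnc32)cc1` gives 960 nM in a functional assay on NCI-H460 cells (Homo sapiens) for antiproliferative activity, read by MTT assay, with a stated time of 72 h (on this read-out lower numbers stand for stronger inhibition and higher numbers for weaker inhibition), the higher of the two numbers in hand; compound 1 `O=C(Nc1ccc(Oc2ccnc3[nH]ccc23)cc1)c1cc2cccnc2n(-c2ccc(F)cc2)c1=O` gives 190 nM. Among the compounds with values here, the only measured step, a 5.1-fold higher number from compound 1 to compound 2 (0.70 log units; beyond the scatter), is the one that bears on the change to compound 3 `O=C(Nc1ccc(Oc2ccnc3[nH]ccc23)cc1)c1cc2cccnc2n(-c2ccc(C(F)(F)F)cc2Cl)c1=O`: 2-chloro-4-(trifluoromethyl)phenyl in place of 4-methoxyphenyl on an aromatic nitrogen. The methoxy that accompanied the higher number leaves, and a chloro and a trifluoromethyl enter. A lower number than compound 2 is therefore expected, and the estimated step is a 3.8-fold lower number from compound 2 to compound 3 (0.58 log units; beyond the scatter). Compound 3 is expected to give about 250 nM, within 80 nM to 800 nM.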

Compound 3, half-maximal inhibitory concentration: 1950 nM
Beside the measured number, compound 3's estimate is 7.8-fold (0.89 log units) below it; the measured number lies above the stated range.
By their numbers in this assay, from the lowest: compound 1; then compound 2; then compound 3.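

Working notes: in this assay the loss of the methoxy did not bring a lower number, since 2-chloro-4-(trifluoromethyl)phenyl gives a 2.0-fold higher number from compound 2 to compound 3 (0.31 log units; beyond the scatter) on this aromatic nitrogen. Against the 4-fluorophenyl the same aryl shows a 10-fold higher number from compound 1 to compound 3 (1.01 log units; beyond the scatter), the widest gap at this position so far, and 4-fluorophenyl stays lowest of the three. No supporting data bear on the reason for this rise.

Chloro and trifluoromethyl entered together, so their separate shares remain unresolved. Going by these compounds, how an aryl carrying an amine or a carboxylic acid would behave on this nitrogen also remains open.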